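The compounds below may be only part of what the source reports. "The series", "measured", "known", "first", "only" and "open" are said of these compounds alone.

Measured in a functional assay on MT4 cells (Homo sapiens); a lower number here means that less compound is tolerated, a higher number that more compound is tolerated:
- compound 1 `Cc1cn([C@@H]2O[C@H](CO[Si](C)(C)C(C)(C)C)[C@@]3(OS(=O)(=O)C=C3NCC(=O)OCc3ccccc3)[C@H]2O[Si](C)(C)C(C)(C)C)c(=O)n(C)c1=O`: 250000 nM
- compound 2 `COC(=O)C(=O)CNC1=CS(=O)(=O)O[C@@]12[C@@H](CO[Si](C)(C)C(C)(C)C)O[C@@H](n1cc(C)c(=O)n(C)c1=O)[C@@H]2O[Si](C)(C)C(C)(C)C`: 10300 nM
- compound 3 `Cc1cn([C@@H]2O[C@H](CO[Si](C)(C)C(C)(C)C)[C@@]3(OS(=O)(=O)C=C3NCCC(=O)O)[C@H]2O[Si](C)(C)C(C)(C)C)c(=O)n(C)c1=O`: 11500 nM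

Compound 3 sits level with compound 2, as a 1.1-fold higher number from compound 2 to compound 3 (0.05 log units; within the scatter) shows. Both lie well under compound 1, through a 22-fold lower number from compound 1 to compound 3 (1.34 log units; beyond the scatter) and a 24-fold lower number from compound 1 to compound 2 (1.39 log units; beyond the scatter). Compound 4 `Cc1cn([C@@H]2O[C@H](CO[Si](C)(C)C(C)(C)C)[C@@]3(OS(=O)(=O)C=C3NCC(=O)C(N)=O)[C@H]2O[Si](C)(C)C(C)(C)C)c(=O)n(C)c1=O` carries carbamoylcarbonyl in place of carboxymethyl on a saturated chain carbon bound to an amine nitrogen. Compound 2 is the nearest reference, with (methoxycarbonyl)carbonyl at that place, and exchanging that group for carboxymethyl gave only a 1.1-fold higher number from compound 2 to compound 3 (0.05 log units; within the scatter). The large steps both start from compound 1, which alone carries benzyloxycarbonyl. Expected in this assay is no step beyond the scatter, the estimate being a 1.2-fold higher number from compound 3 to compound 4 (0.09 log units; within the scatter). For compound 4 the estimated value is 14000 nM, with an expected range of 6000 nM to 40000 nM.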

Compound 4, half-maximal cytotoxic concentration: 9590 nM
Compound 4: the middle estimate sits 1.5-fold (0.16 log units) above what was measured; the measured number falls inside the stated range.
By their numbers in this assay, from the lowest: compounds 4, 2 and 3 (each within the scatter of the next); then compound 1.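

In this assay, carbamoylcarbonyl on the saturated chain carbon bound to an amine nitrogen stays level with both carboxymethyl (a 1.2-fold lower number from compound 3 to compound 4 (0.08 log units; within the scatter)) and (methoxycarbonyl)carbonyl (a 1.1-fold lower number from compound 2 to compound 4 (0.03 log units; within the scatter)), so three different groups at this place now lie within the scatter of each other. Only benzyloxycarbonyl stands apart (a 26-fold lower number from compound 1 to compound 4 (1.42 log units; beyond the scatter)). No measurement shown here explains this separation.

Still open, going by these compounds, is whether a benzyl group without the carbonyl would stand apart in the same way. Also open, on these data alone, is whether an amine or a longer chain at this place would stay level with compound 2, compound 3 and compound 4.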